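The source may hold more compounds than are shown below. What is called first, only, known or untested is meant among the compounds shown, and "the series" means these compounds.

Compound 1, `CSc1cccc(N/C(=N/Nc2ccccc2Cl)C(C)=O)c1`, reaches only the assay limit of > 10000 nM in an assay on isolated protein for binding affinity to corticotropin-releasing factor receptor 1 (Homo sapiens); on this read-out higher numbers stand for weaker inhibition and lower numbers for stronger inhibition. Compound 2, `COc1cccc(N/C(=N/Nc2ccccc2C(F)(F)F)C(C)=O)c1`, gives 6950 nM in this assay. Compound 3, `CCOc1cccc(N/C(=N/Nc2ccccc2C(F)(F)F)C(C)=O)c1`, also reaches only the limit of > 10000 nM in this assay.

Compound 3 thus sits at the weak end of the three, where a limit and no number is reported, as described by the limit of > 10000 nM in this assay, at which 2 of the 3 values shown sit. Compound 4, `CSc1cccc(N/C(=N/Nc2ccccc2C(F)(F)F)C(C)=O)c1`, differs from it in one place: methylsulfanyl in place of ethoxy on an aromatic carbon. Going by the values given here, the only measured step, an at least 1.4-fold higher number from compound 2 to compound 3 (0.15 log units; that floor lies within the scatter), concerns the length of the ether chain rather than this swap, and its floor lies within the scatter, so it offers little guidance. Compound 1 shows that a methylsulfanyl group, paired with a different group on the other ring, also gives only a limit. For compound 4 the expected step is therefore a number no higher from compound 3 to compound 4 (the limit leaves the size open), none beyond the scatter. Compound 4 is estimated at 10000 nM, between 4000 nM and 30000 nM, most likely again only a limit.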

Compound 4, inhibition constant: > 10000 nM
Compound 4 was reported as a limit (the forecaster's own chance of this, stated with the estimate: 60%); the middle value sits exactly at the limit.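

In this assay, exchanging the methoxy group for methylsulfanyl gives an at least 1.4-fold higher number from compound 2 to compound 4 (0.15 log units; that floor lies within the scatter), so the true size of this change stays hidden behind a limit. The steps to compound 4 from compound 3 and from compound 1 cannot be read. With trifluoromethyl held constant, methylsulfanyl now joins ethoxy at the limit, and only compound 2 keeps a number: the limit of > 10000 nM in this assay, at which 3 of the 4 values shown sit.

On these data alone, how an amine or a hydroxy group on this aromatic carbon would read remains open. So does whether any group here gives a measurable number with methylsulfanyl kept.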